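The source may hold more compounds than are shown below. What is called first, only, known or untested is meant among the compounds shown, and "the series" means these compounds.

Notes on the series in a functional assay on Bel-7402 cells (Homo sapiens) for cytotoxicity, read by MTT assay, with a stated time of 48 h; on this read-out lower numbers stand for stronger inhibition and higher numbers for weaker inhibition. Compound 3 (`COc1cc(-n2c(-c3ccccc3)cn(C(C)=O)c2=O)cc(OC)c1OC`) gives > 50000 nM, which is a limit and not a number. Compound 1 (`COc1cc(NC(=O)n2cc(-c3ccc(O)cc3)n(-c3cc(OC)c(OC)c(OC)c3)c2=O)cc(OC)c1OC`) gives > 50000 nM, again a limit. Compound 2 (`COc1ccc(-c2cn(C(=O)Nc3cc(OC)c(OC)c(OC)c3)c(=O)n2-c2cc(OC)c(OC)c(OC)c2)cc1`), which carries a 4-methoxyphenyl, gives > 50000 nM, also a limit. The whole set therefore sits at the limit of > 50000 nM in this assay, at which 3 of the 3 values shown sit, and compound 3 has no numeric position within it.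

Compound 4 (`COc1ccc(-c2cn(C(C)=O)c(=O)n2-c2cc(OC)c(OC)c(OC)c2)cc1`) differs from compound 3 by methoxy in place of hydrogen on an aromatic carbon, with methoxy in place of hydrogen on an aromatic carbon, para to a large group, taking phenyl to 4-methoxyphenyl.

Among the compounds with values here, the only measured step that bears on this is a step that the two limits leave unreadable from compound 1 to compound 2, where methyl replaces hydrogen on an oxygen on an aromatic ring. Its size cannot be read, so it gives weak guidance, and it does not show any gain from the 4-methoxyphenyl in compound 2.

The step expected in this assay is a number no higher from compound 3 to compound 4 (the limit leaves the size open), with no move beyond the scatter foreseen. For compound 4 the estimated value is 50000 nM, with an expected range from 8000 nM to 100000 nM, and a reading at the limit is the likeliest outcome.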

Compound 4, half-maximal inhibitory concentration: 9500 nM
Beside the measured number, compound 4's estimate is 5.3-fold (0.72 log units) above it; the measured number falls inside the stated range.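

In this assay, within the data shown here, methoxy in place of hydrogen on an aromatic carbon, para to a large group, gives an at least 5.2-fold lower number from compound 3 to compound 4 (0.72 log units; beyond the scatter), so this position responds to substitution in a way the earlier compounds could not show. Compound 4 is the only compound here with a number, and the others stand at a limit: the limit of > 50000 nM in this assay, at which 3 of the 4 values shown sit.

Compound 2 carries the same 4-methoxyphenyl and gives > 50000 nM, which is a limit, so the gain holds for this one pair and is no general effect of the group.

The step from compound 1 to compound 2 cannot be read, which leaves the hydroxy and methoxy forms unranked. Open too, from the compounds shown here alone, is how an amine, a fluorine atom or a longer chain such as ethoxy would fare at this position.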